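The source may report more compounds than this note shows. Statements on the series, on what has been measured and on what is new or still open speak of the compounds shown alone.

In a functional assay on the whole organism for agonist activity, with Mus musculus as the target (on this read-out lower numbers stand for an effect already at smaller amounts and higher numbers for an effect only at larger amounts of compound), compound 2 `CC(=O)N(C)CC#CCn1ccnc1` gives 0.97 mg/kg and compound 3 `CC(=O)N(C)CC#CCn1cncc1C` gives 5.4 mg/kg, the higher of these two numbers. Compound 1 `CC(=O)NCC#CCn1cncc1C` is reported only as a limit, > 100 mg/kg. Going on to compound 4 `COC(=O)NCC#CCn1cncc1C`, the change is (methoxycarbonyl)amino in place of acetyl(methyl)amino on a saturated chain carbon bound to a triple-bonded carbon. The step of an at least 18-fold lower number from compound 1 to compound 3 (1.26 log units; beyond the scatter) bears most on this, since compound 4 also has a hydrogen, not a methyl, on the amide-type nitrogen. The step of a 5.6-fold higher number from compound 2 to compound 3 (0.75 log units; beyond the scatter) bears less, since compound 4 keeps that methyl on an aromatic carbon. Going by the values given here, no measured step covers the (methoxycarbonyl)amino group itself. A large rise in the number is therefore expected, estimated as an 11-fold higher number from compound 3 to compound 4 (1.05 log units; beyond the scatter). For compound 4 the estimate is 60 mg/kg, with an expected range from 15 mg/kg to 250 mg/kg.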

Compound 4, dose for half-maximal effect: > 100 mg/kg
Compound 4: only a limit was reported; the forecaster's own chance of this, stated with the estimate: 45%; middle value at least 1.6-fold (0.22 log units) away from the limit.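

The (methoxycarbonyl)amino group on a saturated chain carbon bound to a triple-bonded carbon gives an at least 18-fold higher number from compound 3 to compound 4 (1.26 log units; beyond the scatter) in this assay, so the effect seen with compound 3 is not kept. Compound 1 and compound 4 both carry the amide hydrogen and both are reported only as a limit, so the step between them cannot be read and methoxy in place of methyl on the carbonyl carbon stays unjudged: the limit of > 100 mg/kg in this assay, at which 2 of the 4 values shown sit.

The amide hydrogen and the methoxy enter together in this change, and the compounds shown do not separate them. As far as these compounds go, a (methoxycarbonyl)(methyl)amino group at this place would keep the methyl on that nitrogen and remains open.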